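A few compounds are considered here, and "the series" means these few. Any claim that something is new, unique, unknown or untested is made for them only; others in the source may bear on it.

Compound 1 `O=C(O)/C=C/c1ccncc1-c1ccc2cc[nH]c2c1` carries a carboxy group. In a functional assay on KB cells (Homo sapiens) for inhibition, read by sulforhodamine B assay, with a stated time of 72 h (a higher number here means a weaker inhibitor of growth, a lower number a stronger inhibitor of growth), compound 1 gives only a limit, > 10000 nM, so where it stands among the measured compounds is known as a floor and not as a number. The measured pair that matches the change is compound 2 `COC(=O)/C=C/c1ccncc1-c1ccc2ccccc2c1`, with methyl on an oxygen next to a carbonyl group, and compound 3 `O=C(O)/C=C/c1ccncc1-c1ccc2ccccc2c1`, with hydrogen there, on a different core. In this assay compound 2 gives 6730 nM. Compound 3 gives only a limit in this assay, > 10000 nM. For the measured compounds named here, the step of an at least 1.4-fold higher number from compound 2 to compound 3 (0.17 log units; that floor lies within the scatter) is the one measured step that bears on the change to compound 4 `CCOC(=O)/C=C/c1ccncc1-c1ccc2cc[nH]c2c1`; its floor lies within the scatter, and the limit of > 10000 nM in this assay, at which 2 of the 3 values shown sit, is why its size is a floor only. Compound 4 differs from compound 1 by ethyl in place of hydrogen on an oxygen next to a carbonyl group, the reverse direction of that measured step. By analogy the expected step is an at least 1.2-fold lower number from compound 1 to compound 4 (0.09 log units; that floor lies within the scatter), toward a lower number if anything, but not clearly beyond the scatter. Compound 4 is therefore estimated near 8000 nM, between 3000 nM and 30000 nM.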

Compound 4, concentration for 50% growth inhibition: 7860 nM
Beside the measured number, compound 4's estimate is 1.0-fold (0.01 log units) above it; the measured number falls inside the stated range.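

In this assay, the core of compound 1 now has a measured number: compound 4 gives 7860 nM. Compound 1 itself remains a limit of the assay, > 10000 nM, so hydroxy to ethoxy at this oxygen on the carbonyl group reads only as an at least 1.2-fold lower number from compound 1 to compound 4 (0.10 log units; that floor lies within the scatter). That floor, like an at least 1.4-fold higher number from compound 2 to compound 3 (0.17 log units; that floor lies within the scatter) on the other core, does not establish a change beyond the scatter, and the sizes of both steps stay open because of the assay limit: the limit of > 10000 nM in this assay, at which 2 of the 4 values shown sit.

How far the carboxy and ethoxycarbonyl forms truly lie apart on either core remains unresolved. Also open, from the compounds shown here alone, is what a longer chain on this oxygen, or an amine in place of the ethoxy, would give on the core of compound 4.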